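The source may hold more compounds than are shown below. What is called first, only, known or untested is meant among the compounds shown, and "the series" means these compounds.

Measured so far:
Compound 1, `COc1cc2c(Nc3nc4ccc(C(=O)Nc5c(C)cccc5C)cc4s3)ncnc2cc1OCCCN1CCCCC1C`: in a functional assay on DLD-1 cells (Homo sapiens) for cytotoxicity, read by WST assay, with a stated time of 72 h (a lower number here means a stronger inhibitor, a higher number a weaker inhibitor), compound 1 gives only a limit, > 100000 nM.
Compound 2, `COc1cc2c(Nc3nc4ccc(C(=O)Nc5c(C)cc(C)cc5C)cc4s3)ncnc2cc1OCCCN1CCCCC1C`: in this assay compound 2 gives 5700 nM.

For the measured compounds named here, compound 2 carries the only number seen so far; the other value is the limit of > 100000 nM in this assay, at which 1 of the 2 values shown sits. Going by the values given here, the one measured step, an at least 17-fold lower number from compound 1 to compound 2 (1.24 log units; beyond the scatter), concerns methyl in place of hydrogen on an aromatic carbon, at the amide end of the shared core. Compound 3, `COc1cc2c(Nc3nc4ccc(C(=O)Nc5c(C)cc(C)cc5C)cc4s3)ncnc2cc1OCCCN1CCCC1`, differs from compound 2 elsewhere: pyrrolidin-1-yl in place of 2-methylpiperidin-1-yl on a saturated chain carbon, three bonds along the chain from an oxygen on an aromatic ring. Among the compounds with values here, no measured step touches that end of the chain, so the measured step offers no guide to this change. With nothing to point either way, the expectation for compound 3 in this assay is a step of about no change at the digits printed from compound 2 to compound 3 (within the scatter), that is, no change beyond the scatter. The value of compound 3 is therefore estimated at 5700 nM, with a range from 1500 nM to 22000 nM.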

Compound 3, half-maximal inhibitory concentration: 5900 nM
Compound 3: the middle estimate sits 1.0-fold (0.01 log units) below what was measured, within the range that was stated.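

In this assay, putting pyrrolidin-1-yl in place of 2-methylpiperidin-1-yl, on a saturated chain carbon, three bonds along the chain from an oxygen on an aromatic ring, gives a 1.0-fold higher number from compound 2 to compound 3 (0.01 log units; within the scatter). For the compounds shown here, this is the first look at this end of the chain: going from a six-membered to a five-membered ring and losing the ring methyl leaves the reading within the scatter, whereas one added methyl at the amide end gave an at least 17-fold lower number from compound 1 to compound 2 (1.24 log units; beyond the scatter). Nothing measured here bears on why this ring change leaves the reading where it is.

On these data alone, only these two rings have been compared at this position, so it remains open whether morpholin-4-yl or an open-chain dimethylamine would read the same. As far as these compounds go, a longer chain between the oxygen and the ring, or a carboxylic acid at the chain end, is equally open.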